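The source may report more compounds than this note shows. Statements on the series, on what has been measured and on what is new or still open speak of the compounds shown alone.

Three carbamates were measured in a functional assay on MCF7 cells (Homo sapiens) for cytotoxicity, read by MTT assay, with a stated time of 72 h; on this read-out lower numbers stand for higher toxicity in this test and higher numbers for lower toxicity in this test. Compound 1 `N#C[Se]c1ccc(NC(=O)OCc2ccc([N+](=O)[O-])cc2)cc1` gives 69500 nM in this assay. Compound 2 `CC(C)COC(=O)Nc1ccc([Se][Se]c2ccc(NC(=O)OCC(C)C)cc2)cc1` gives 80500 nM in this assay. Compound 3 `C=CCOC(=O)Nc1ccc([Se]C#N)cc1` gives 71200 nM in this assay, the second highest of the three numbers; its gap to compound 1 and its gap to compound 2 both lie within the scatter, so the three compounds cannot be told apart on these data. Compound 4 `N#C[Se]c1ccc(NC(=O)OCc2ccccc2)cc1` has not yet been measured. It differs from compound 3 by phenyl in place of vinyl on a saturated chain carbon bound to an oxygen next to a carbonyl group. Because compound 1, also carrying a phenyl, gives 69500 nM in this assay, the step of a 1.0-fold lower number from compound 3 to compound 4 (0.01 log units; within the scatter) is expected to be none beyond the scatter. Compound 4 is therefore estimated at 70000 nM, in a range from 35000 nM to 140000 nM.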

Compound 4, concentration lethal to 50% of the cells: 68900 nM
The estimate for compound 4 lay 1.0-fold (0.01 log units) above the measured number, within the range that was stated.
By their numbers in this assay, from the lowest: compounds 4, 1, 3 and 2 (each within the scatter of the next).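

The step of a 1.0-fold lower number from compound 3 to compound 4 (0.01 log units; within the scatter) for phenyl in place of vinyl on a saturated chain carbon bound to an oxygen next to a carbonyl group shows that, in this assay, this exchange leaves the number within the scatter. The step of a 1.0-fold lower number from compound 1 to compound 4 (0.00 log units; within the scatter) for hydrogen in place of nitro on an aromatic carbon shows that the nitro group can also go without a change beyond the scatter. Nothing available explains why these numbers stay so close.

Going by these compounds, whether an amine or a carboxylic acid in place of that nitro, or a longer chain in place of the phenyl, would move the number beyond the scatter remains open.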